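Cytotoxicity notes on a naphthyloxy triazine series

This account rests on a few compounds, and the source may have more. Where it says the series, first, only, none or still open, it means among the compounds named here.

Measured in an ADME assay on MT4 cells (Homo sapiens) for cytotoxicity, read by MTT assay, with a stated time of 4 days; on this read-out lower numbers stand for higher toxicity in this test and higher numbers for lower toxicity in this test:
compound 1 `CNc1nc(Nc2ccc(C#N)cc2)nc(Oc2cccc3ccccc23)n1` gives 30300 nM
compound 2 `N#Cc1ccc(Nc2nc(N)nc(Oc3cccc4ccccc34)n2)cc1` gives 39100 nM
compound 3 `CNc1nc(Nc2ccc(C#N)cc2)nc(Oc2ccc3ccccc3c2)n1` gives 250000 nM

Compound 1 and compound 2 differ by hydrogen in place of methyl on a nitrogen on an aromatic ring, and the step of a 1.3-fold higher number from compound 1 to compound 2 (0.11 log units; within the scatter). Compound 3 shares all atoms with compound 1 but joined differently; the difference between the two cores is not broken down here. Compound 3 stands highest of the three in this assay, beyond the scatter from both others.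

Compound 4 `N#Cc1ccc(Nc2nc(N)nc(Oc3ccc4ccccc4c3)n2)cc1` is not yet measured. It differs from compound 3 by hydrogen in place of methyl on a nitrogen on an aromatic ring, the same change as that from compound 1 to compound 2. Because the step of a 1.3-fold higher number from compound 1 to compound 2 (0.11 log units; within the scatter) stayed within the scatter, compound 4 is expected to stay close to compound 3, with an expected step of a 1.1-fold higher number from compound 3 to compound 4 (0.05 log units; within the scatter). The estimate for compound 4 in this assay is 280000 nM, expected between 140000 nM and 560000 nM.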

Compound 4, half-maximal cytotoxic concentration: 42200 nM
Compound 4: the middle estimate sits 6.6-fold (0.82 log units) above what was measured, outside the stated range (below it).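

In this assay, methylamino to amino gives a 5.9-fold lower number from compound 3 to compound 4 (0.77 log units; beyond the scatter). Set beside the earlier step on the core of compound 1, this change does not carry over as a constant step between the two cores: the same change on two cores in this assay, a 1.3-fold higher number (0.11 log units; within the scatter) from compound 1 to compound 2 and a 5.9-fold lower number (0.77 log units; beyond the scatter) from compound 3 to compound 4, 7.6-fold (0.88 log units) apart, beyond the scatter of two such steps The size of the step therefore depends on the core in these two pairs, but two pairs do not show why, nor how the change would behave on any further core.

Open, as far as these compounds go, is whether an ethyl group or a longer chain on this nitrogen would follow the step seen on the core of compound 1 or the one seen on the core of compound 3. Also open, from the compounds shown here alone, is whether a carboxylic acid in place of the nitrile would leave this core dependence intact.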